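The source may report more compounds than this note shows. Statements on the series, on what has been measured and on what is new or still open speak of the compounds shown alone.

Compounds measured in an ADME assay on L02 cells (Homo sapiens) for cytotoxicity, read by MTT assay, with a stated time of 48 h; on this read-out lower numbers stand for stronger inhibition and higher numbers for weaker inhibition:

compound 1 `CCn1c(C(=O)NCCN(C)C)ccc1C(CC)(CC)c1ccc(OCC(=O)C(C)(C)C)c(C)c1` — 2500 nM
compound 2 `CCn1c(C(=O)NCCCN(C)C)ccc1C(CC)(CC)c1ccc(OCC(=O)C(C)(C)C)c(C)c1` — 670 nM
compound 3 `CCn1c(C(=O)NCCCN(C)C)ccc1C(CC)(CC)c1ccc(OCC(O)C(C)(C)C)c(C)c1` — 470 nM

Compound 3 gives the lowest of the three numbers. Its nearest neighbour is compound 2, and the two lie within the scatter of each other, so no order between them can be claimed; compound 1 stands furthest away, with a step to compound 3 that is beyond the scatter.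

Compound 4 `CCn1c(C(=O)Oc2ccc(CCO)cc2)ccc1C(CC)(CC)c1ccc(OCC(O)C(C)(C)C)c(C)c1` differs from compound 3 in one place: a group of 10 heavy atoms (8 carbon, 2 oxygen; one six-membered aromatic ring of carbon only) in place of a group of 7 heavy atoms (5 carbon, 2 nitrogen; no ring), on a carbonyl carbon

Neither measured step bears directly on this change. The step of a 3.7-fold lower number from compound 1 to compound 2 (0.57 log units; beyond the scatter) concerns the length of the chain carrying the dimethylamino group, while the step of a 1.4-fold lower number from compound 2 to compound 3 (0.15 log units; within the scatter) concerns the group on the saturated chain carbon bound to an oxygen on the aromatic ring. Among the measured compounds shown here, the change from compound 3 to compound 4 removes the whole (3-(dimethylamino)propyl)amino group and puts an aryl ester in its place, a change of a kind no measured pair covers. The estimate for compound 4 therefore stays close to compound 3 and carries a wide range. For compound 4 in this assay the expected value is 800 nM, between 300 nM and 3000 nM. The expected step of a 1.7-fold higher number from compound 3 to compound 4 (0.23 log units; within the scatter) is a modest rise in the number, and may well lie within the scatter.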

Compound 4, half-maximal inhibitory concentration: 22700 nM
Beside the measured number, compound 4's estimate is 28-fold (1.45 log units) below it, and the stated range ends below it.
By their numbers in this assay, from the lowest: compounds 3 and 2 (each within the scatter of the next); then compound 1; then compound 4.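

In this assay, the group on the carbonyl carbon carries far more weight than the groups changed earlier: exchanging (3-(dimethylamino)propyl)amino for the group with the six-membered aromatic ring gives a 48-fold higher number from compound 3 to compound 4 (1.68 log units; beyond the scatter), the large step of the series. That step exceeds both a 3.7-fold lower number from compound 1 to compound 2 (0.57 log units; beyond the scatter), which concerns the chain length alone, and a 1.4-fold lower number from compound 2 to compound 3 (0.15 log units; within the scatter), so among the places varied here, this carbonyl carbon is where the number moves most. Nothing measured here accounts for the rise.

This single exchange alters the atom bound to the carbonyl carbon, removes the dimethylamino group and brings in the aromatic ring all at once, and the compounds shown do not separate these parts. An amide carrying the same aromatic ring, an ester keeping the dimethylamino group on its chain, or a carboxylic acid at this carbonyl carbon would each bear on which part goes with the higher number.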